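Ester series on a bicyclic diol core: plasma half-life notes

The source may report more compounds than this note shows. Statements on the series, on what has been measured and on what is new or still open speak of the compounds shown alone.

Measured compounds:
- compound 1 `CC(=O)Oc1ccccc1C(=O)O[C@H]1CO[C@H]2[C@@H]1OC[C@H]2O`: 0.055 h
- compound 2 `CCC(=O)O[C@@H]1CO[C@H]2[C@@H]1OC[C@@H]2OC(=O)c1ccccc1OC(C)=O`: 0.0608 h
- compound 3 `CC(=O)Oc1ccccc1C(=O)O[C@H]1CO[C@H]2[C@@H]1OC[C@H]2OC(=O)C1CC1`: 0.0322 h

In an ADME assay on a cell-free system (plasma, Homo sapiens) for metabolic stability, with Plasma (Rattus norvegicus) as the target, read by HPLC, at pH 7.4 (on this read-out higher numbers stand for a longer-lived compound and lower numbers for a shorter-lived compound), compound 1 gives 0.055 h and stands second highest of the three numbers; its nearest neighbour is compound 2 with a 1.1-fold higher number from compound 1 to compound 2 (0.04 log units; within the scatter), its furthest compound 3 with a 1.7-fold lower number from compound 1 to compound 3 (0.23 log units; within the scatter). Both steps replace the same hydrogen on an oxygen on a saturated carbon with an acyl group and neither moves the number beyond the scatter.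

Compound 4 `CC(=O)Oc1ccccc1C(=O)O[C@H]1CO[C@H]2[C@@H]1OC[C@H]2OC(=O)c1ccc(C#N)cc1` is not yet measured in this assay. It differs from compound 1 by (4-cyanophenyl)carbonyl in place of hydrogen on an oxygen on a saturated carbon. The two measured steps from compound 1, to compound 2 and to compound 3, are the ones that bear on this change; both were small and within the scatter. The change from compound 1 to compound 4 is therefore expected to give no step beyond the scatter in this assay, i.e. a 1.1-fold lower number from compound 1 to compound 4 (0.04 log units; within the scatter). Compound 4 is expected to give about 0.05 h, with a range of 0.025 h to 0.1 h.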

Compound 4, half-life: 0.0888 h
Beside the measured number, compound 4's estimate is 1.8-fold (0.25 log units) below it; low and high end bracket the measured number.
By their numbers in this assay, from the lowest: compounds 3, 1, 2 and 4 (each within the scatter of the next, the first and the last beyond it).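

In this assay, placing (4-cyanophenyl)carbonyl in place of hydrogen on the oxygen on a saturated carbon still leaves the number within the scatter (  a 1.6-fold higher number from compound 1 to compound 4 (0.21 log units; within the scatter)), so this larger aromatic acyl group is tolerated as the two smaller acyl groups were. Among the compounds shown here, the identity of the acyl group now gives the first step beyond the scatter, a modest one (a 2.8-fold higher number from compound 3 to compound 4 (0.44 log units; beyond the scatter)), although the corresponding comparison with the propanoyl ester stays within the scatter (a 1.5-fold higher number from compound 2 to compound 4 (0.16 log units; within the scatter)), so the separation holds against the cyclopropyl group alone. Nothing available explains this difference between the two comparisons.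

On these data alone, whether the nitrile contributes to the step remains open, as a plain benzoyl group would be needed to separate it from the aromatic ring. A longer chain such as hexanoyl, or an acyl group carrying an amine, also leaves the range of this position untested.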